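The source may report more compounds than this note shows. Statements on the series, on what has been measured and on what is new or still open speak of the compounds shown alone.

Measured compounds:
- compound 1, `COc1ccc(NC(=O)Nc2cccc(CNc3nccnc3Cl)c2)cc1`, 9820 nM
- compound 2, `COc1ccccc1NC(=O)Nc1cccc(CNc2nccnc2Cl)c1`, 10400 nM
- compound 3, `O=C(Nc1cccc(Cl)c1)Nc1cccc(CNc2nccnc2Cl)c1`, 6810 nM

All three values come from a functional assay on T-24 cells (Homo sapiens) for antiproliferative activity, read by MTT assay, with a stated time of 48 h; on this read-out lower numbers stand for stronger inhibition and higher numbers for weaker inhibition. Compound 3 gives the lowest number of the three, but the steps of a 1.4-fold lower number from compound 1 to compound 3 (0.16 log units; within the scatter) and a 1.5-fold lower number from compound 2 to compound 3 (0.18 log units; within the scatter) are within the scatter, as is the step of a 1.1-fold higher number from compound 1 to compound 2 (0.02 log units; within the scatter). On these numbers the three compounds are indistinguishable.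

Compound 4, `O=C(Nc1cccc(CNc2nccnc2Cl)c1)NC1CCCC1`, has not yet been measured in this assay. The change from compound 3 is cyclopentyl in place of 3-chlorophenyl on an amide-type nitrogen. Among the compounds with values here, none of the measured steps bears directly on it: each of them exchanges one aryl group for another aryl group on the same amide-type nitrogen, and each stays within the scatter. There is no measured exchange of an aromatic ring for a non-aromatic one in this set, so the expectation can rest only on the observation that the three aryl variants behave alike.

Compound 4 is therefore expected to give 9000 nM in this assay, with a range of 3000 nM to 30000 nM, the wide range reflecting the absence of a comparable step. The step expected from compound 3 is a 1.3-fold higher number from compound 3 to compound 4 (0.12 log units; within the scatter), not clearly beyond the scatter in either direction.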

Compound 4, half-maximal inhibitory concentration: > 40000 nM
Compound 4: no number, only a limit; the forecaster's own chance of this, stated with the estimate: 15%; middle value at least 4.4-fold (0.64 log units) away from the limit.
By their numbers in this assay, from the lowest: compounds 3, 1 and 2 (each within the scatter of the next). At a limit, above all of these: compound 4.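

In this assay, compound 4 carries only a limit of the assay and not a number: the limit of > 40000 nM in this assay, at which 1 of the 4 values shown sits. The exchanges among the three aryl groups on the amide-type nitrogen all stayed within the scatter, but cyclopentyl in place of each of them moves beyond it, with an at least 5.8-fold higher number from compound 3 to compound 4 (0.76 log units; beyond the scatter), an at least 3.8-fold higher number from compound 2 to compound 4 (0.58 log units; beyond the scatter) and an at least 4.0-fold higher number from compound 1 to compound 4 (0.60 log units; beyond the scatter). This position therefore does not accept every ring alike: within the compounds shown, the read-out stays level across 3-chlorophenyl and the two methoxyphenyl groups and separates only on going to a five-membered non-aromatic ring of carbon only, and no compound shown goes against this.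

A single non-aromatic group cannot show whether the separation follows from losing the aromatic ring or from the smaller ring, and the limit leaves the true size of all three steps open. A cyclohexyl group on the same nitrogen would hold the six-membered ring while removing the aromatic character, and a benzyl group or an open pentyl chain would test how far an aryl ring or any ring is needed here.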